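Aryl-to-alkenyl switch on the pyrimidine series: compound 4

The source may hold more compounds than are shown below. What is called first, only, known or untested is meant among the compounds shown, and "the series" means these compounds.

Measured so far:
compound 1 `CCOC(=O)c1cnc(-c2ccc(F)cc2)nc1NN1C(=O)C=C(C)C1=O` — 700 nM
compound 2 `CCOC(=O)c1cnc(-c2ccc(Cl)cc2)nc1NN1C(=O)C=C(C)C1=O` — 300 nM
compound 3 `CCOC(=O)c1cnc(-c2ccc(C)s2)nc1NN1C(=O)C=C(C)C1=O` — 200 nM

All three share one core and differ only in the group on the aromatic carbon between two ring nitrogen atoms. In a functional assay on Jurkat cells for inhibition of nuclear factor NF-kappa-B complex (Homo sapiens) (a higher number here means a weaker inhibitor, a lower number a stronger inhibitor), compound 3 gives the lowest of the three numbers; against compound 2 the gap is a 1.5-fold lower number from compound 2 to compound 3 (0.18 log units; within the scatter), which does not separate the two, while against compound 1 it is a 3.5-fold lower number from compound 1 to compound 3 (0.54 log units; beyond the scatter). The remaining step, a 2.3-fold lower number from compound 1 to compound 2 (0.37 log units; beyond the scatter), is also modest.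

Compound 4 `CCOC(=O)c1cnc(CC2=CCCCC2)nc1NN1C(=O)C=C(C)C1=O` carries (cyclohex-1-en-1-yl)methyl in place of 5-methylthiophen-2-yl on an aromatic carbon. Among the measured compounds shown here, none of the measured steps covers this kind of change: all three swap one aromatic group for another, and even those moved this assay only modestly. As far as these compounds go, a non-aromatic group with no hydrogen-bond acceptor at this position is untested in the set, so the direction is uncertain; a step toward a higher number is expected as the more likely outcome, a 4.0-fold higher number from compound 3 to compound 4 (0.60 log units; beyond the scatter), with a wide range. Compound 4 is therefore estimated at 800 nM, between 200 nM and 3000 nM.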

Compound 4, half-maximal inhibitory concentration: 2000 nM
Compound 4: the middle estimate sits 2.5-fold (0.40 log units) below what was measured, and the stated range covers the measured number.
By their numbers in this assay, from the lowest: compounds 3 and 2 (each within the scatter of the next); then compound 1; then compound 4.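

In this assay the swap to (cyclohex-1-en-1-yl)methyl gives a 10-fold higher number from compound 3 to compound 4 (1.00 log units; beyond the scatter) and a 6.7-fold higher number from compound 2 to compound 4 (0.82 log units; beyond the scatter) and a 2.9-fold higher number from compound 1 to compound 4 (0.46 log units; beyond the scatter) against the aromatic groups. This position therefore responds more to leaving the aromatic groups than the swaps among them showed, with all three aromatic compounds lower than compound 4 and none going against that order in this small set. No measurement at hand explains the rise.

The change also adds a methylene link while removing the aromatic ring, so the compounds shown cannot say which of the two goes with the higher number; a benzyl group and a directly attached cyclohex-1-en-1-yl group would separate them. As far as these compounds go, how an amine such as morpholine or a carboxylic acid behaves at this position also remains open.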